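Pyrazinyl to pyrimidinyl amide swap on quinolinyl series

This account rests on a few compounds, and the source may have more. Where it says the series, first, only, none or still open, it means among the compounds named here.

Measured compounds:
compound 1 `Cc1cnc(C(=O)Nc2cc(Cl)cc3cccnc23)cn1` — 1500 nM
compound 2 `O=C(Nc1cc(Cl)cc2cccnc12)c1ncccn1` — 800 nM
compound 3 `Cc1cnc(C(=O)Nc2cc(OCCNC(=O)OC(C)(C)C)cc3cccnc23)cn1` — 670 nM

All three were run in a functional assay on MIA PaCa-2 cells (Homo sapiens) for inhibition, read by MTT assay, with a stated time of 72 h; on this read-out higher numbers stand for weaker inhibition and lower numbers for stronger inhibition. Compound 1 `Cc1cnc(C(=O)Nc2cc(Cl)cc3cccnc23)cn1` gives 1500 nM in this assay. Compound 2 `O=C(Nc1cc(Cl)cc2cccnc12)c1ncccn1` differs from compound 1 by pyrimidin-2-yl in place of 5-methylpyrazin-2-yl on a carbonyl carbon; in this assay compound 2 gives 800 nM, and the step is a 1.9-fold lower number from compound 1 to compound 2 (0.27 log units; within the scatter). Compound 3 `Cc1cnc(C(=O)Nc2cc(OCCNC(=O)OC(C)(C)C)cc3cccnc23)cn1` carries a different core; how that core differs from the core of compound 1 is not broken down here. In this assay compound 3 gives 670 nM.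

Compound 4 `CC(C)(C)OC(=O)NCCOc1cc(NC(=O)c2ncccn2)c2ncccc2c1` is not yet measured. It differs from compound 3 by pyrimidin-2-yl in place of 5-methylpyrazin-2-yl on a carbonyl carbon, the same change as from compound 1 to compound 2, made at the same place on a carbonyl carbon. Among the measured compounds shown here, the only measured instance of this change is a small step within the scatter, so a step of similar size is expected here. The expected step is a 1.7-fold lower number from compound 3 to compound 4 (0.22 log units; within the scatter), resting on the step of a 1.9-fold lower number from compound 1 to compound 2 (0.27 log units; within the scatter) applied to the value of compound 3 670 nM. Compound 4 is therefore estimated at 400 nM, with a range from 200 nM to 800 nM.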

Compound 4, half-maximal inhibitory concentration: > 10000 nM
Compound 4: no number, only a limit; the forecaster's own chance of this, stated with the estimate: 3%; at least 25-fold (1.39 log units) between middle value and limit.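

In this assay compound 4 gives > 10000 nM, which is a limit of the assay and not a number. Read against that limit, pyrimidin-2-yl in place of 5-methylpyrazin-2-yl on a carbonyl carbon gives an at least 14-fold higher number from compound 3 to compound 4 (1.17 log units; beyond the scatter), and the result on the core of compound 1 does not carry over to the core of compound 3: the same change on two cores in this assay, a 1.9-fold lower number (0.27 log units; within the scatter) from compound 1 to compound 2 and an at least 14-fold higher number (1.17 log units; beyond the scatter) from compound 3 to compound 4, at least 27-fold (1.44 log units) apart, beyond the scatter of two such steps. With one pair on each core, this shows that the outcome of the change depended on the core in these four compounds, but it does not show which feature of the core is responsible, how large the true step is, or how the change would behave on any further core.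

From the compounds shown here alone, it remains open whether the difference follows the chain shared by compound 3 and compound 4 or another feature of their core. Matched pairs carrying a primary amine or a carboxylic acid at the end of that chain, or a longer chain, each with both amide groups, would test this.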